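The source may hold more compounds than are shown below. What is called first, only, known or untested is meant among the compounds shown, and "the series" means these compounds.

Compound 1 `CC1(C)CC(NC(=O)NCc2ccccc2)c2cc(Cl)ccc2O1`: 66000 nM
Compound 2 `CC(=O)NC1CC(C)(C)Oc2ccc(Cl)cc21`: > 100000 nM, a limit
Compound 3 `CCNC(=O)NC1CC(C)(C)Oc2ccc(Cl)cc21`: > 100000 nM, a limit

All three compounds were tested in a functional assay on U-373MG ATCC cells (Homo sapiens) for inhibition, read by MTT assay, with a stated time of 72 h; on this read-out higher numbers stand for weaker inhibition and lower numbers for stronger inhibition. Only compound 1 gives an actual number. Compound 3 has a limit rather than a number, and it stands at the limit of > 100000 nM in this assay, at which 2 of the 3 values shown sit.

Compound 4 `CCOC(=O)NC1CC(C)(C)Oc2ccc(Cl)cc21` keeps the shared core and changes one group: ethoxy in place of ethylamino on a carbonyl carbon. Put simply, (ethylcarbamoyl)amino becomes (ethoxycarbonyl)amino.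

The closest measured step acts on the same carbonyl carbon: a step that the two limits leave unreadable from compound 2 to compound 3. It shows that two different groups at this place both end at the limit, but it gives no size. Two other steps offer only floors: an at least 1.5-fold higher number from compound 1 to compound 2 (0.18 log units; that floor lies within the scatter), and an at least 1.5-fold higher number from compound 1 to compound 3 (0.18 log units; that floor lies within the scatter). Within the data shown here, no measured step therefore shows a change at this carbonyl carbon moving a number within the range the assay can read.

With nothing pointing either way, no shift beyond the scatter is expected, and the estimated change is a number no higher from compound 3 to compound 4 (the limit leaves the size open). A report of only a limit is the likeliest outcome for the next compound. The estimate for compound 4 is 100000 nM, with an expected range from 50000 nM to 200000 nM.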

Compound 4, half-maximal inhibitory concentration: > 100000 nM
Compound 4 gave a limit, no number; the forecaster's own chance of this, stated with the estimate: 75%; the middle value sits exactly at the limit.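

Replacing ethylamino with ethoxy on a carbonyl carbon exchanges a hydrogen-bond donor for a hydrogen-bond acceptor, and in this assay this change still gives no readable number. Compound 4 joins the compounds that report only a limit: the limit of > 100000 nM in this assay, at which 3 of the 4 values shown sit. Among these compounds, the steps linking compound 4 to compound 2 and compound 3 cannot be read, and the one comparison with a measured number gives only an at least 1.5-fold higher number from compound 1 to compound 4 (0.18 log units; that floor lies within the scatter).

The compounds shown therefore leave open whether these small groups truly differ from one another, as any differences would lie out of reach of this assay's limit. They also leave open whether a longer chain, such as butylamino, or a benzyloxy group on this carbonyl carbon would give a number that could be read.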